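From sulfonyl to oxadiazole on the ring amine nitrogen

A few compounds are considered here, and "the series" means these few. Any claim that something is new, unique, unknown or untested is made for them only; others in the source may bear on it.

Compound 2 `CC(C)S(=O)(=O)N1CCC(Oc2ncnc3c2CCN3c2ccc(S(C)(=O)=O)cc2F)CC1` stands as the weaker of the two measured compounds: in a functional assay on CHO-K1 cells for agonist activity at Glucose-dependent insulinotropic receptor (Homo sapiens), read by a luciferase reporter, with a stated time of 5 h (a lower number here means that less compound is needed, a higher number that more compound is needed for the effect), compound 2 gives 1260 nM, whereas compound 1 `CCCOC(=O)N1CCC(Oc2ncnc3c2CCN3c2ccc(S(C)(=O)=O)cc2F)CC1` gives 79.4 nM. Going by the values given here, the only measured step, a 16-fold higher number from compound 1 to compound 2 (1.20 log units; beyond the scatter), shows that the group on the ring amine nitrogen matters greatly. Compound 3 `CC(C)c1noc(N2CCC(Oc3ncnc4c3CCN4c3ccc(S(C)(=O)=O)cc3F)CC2)n1` changes that same group: 3-isopropyl-1,2,4-oxadiazol-5-yl in place of isopropylsulfonyl on an amine nitrogen in a ring. Among the compounds with values here, because the one measured step of a 16-fold higher number from compound 1 to compound 2 (1.20 log units; beyond the scatter) was large, a sizeable shift is expected here too, towards a lower number, so compound 3 is expected to show a 6.3-fold lower number from compound 2 to compound 3 (0.80 log units; beyond the scatter). The estimate for compound 3 in this assay is 200 nM, with a range from 50 nM to 800 nM.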

Compound 3, half-maximal effective concentration: 79.4 nM
Estimate against measurement, compound 3: 2.5-fold (0.40 log units) above; low and high end bracket the measured number.
By their numbers in this assay, from the lowest: compounds 1 and 3 (each within the scatter of the next); then compound 2.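

Moving from isopropylsulfonyl to 3-isopropyl-1,2,4-oxadiazol-5-yl on the ring amine nitrogen gives a 16-fold lower number from compound 2 to compound 3 (1.20 log units; beyond the scatter), so the loss seen with the sulfonyl group is not a general penalty at this position. Against propoxycarbonyl there is no change at the digits printed from compound 1 to compound 3 (within the scatter), which shows that a five-membered aromatic ring can match that group here without its carbonyl. Nothing available explains this match.

As far as these compounds go, it remains open how much the isopropyl group on the oxadiazole contributes, and whether a methyl or tert-butyl group there would keep the same number. A pyrimidine ring on the same nitrogen is also an open case.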